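Chloro in Place of Nitro, Tested a Second Time

The source may hold more compounds than are shown below. What is called first, only, known or untested is meant among the compounds shown, and "the series" means these compounds.

Of the compounds shown here, three of one family have been measured in a physicochemical assay, read by spectrophotometry, with a stated time of 30 min; a higher number here means a weaker inhibitor, a lower number a stronger inhibitor. Compound 1 `O=[N+]([O-])c1cccc(Cn2cc(COc3ccccc3)nn2)c1` gives 25.3 ug/mL in this assay. Compound 2 `Clc1cccc(Cn2cc(COc3ccccc3)nn2)c1` gives 27.3 ug/mL in this assay. The two differ in one place: chloro in place of nitro on an aromatic carbon. That change produced a 1.1-fold higher number from compound 1 to compound 2 (0.03 log units; within the scatter). Compound 3 `O=[N+]([O-])c1ccc(Cn2cc(COc3ccc(Cl)cc3)nn2)cc1` gives 24.2 ug/mL in this assay. The difference between the core of compound 3 and the core of compound 1 is not broken down here; their two values fall within the scatter of each other, as do the values of compound 3 and compound 2.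

Compound 4 `Clc1ccc(Cn2cc(COc3ccc(Cl)cc3)nn2)cc1` has not yet been measured in this assay. It differs from compound 3 in one place: chloro in place of nitro on an aromatic carbon. For the measured compounds named here, this is the same kind of change as the one from compound 1 to compound 2, with a difference in where it sits: in the earlier pair the place is meta to a large group, here it is para to a large group.

For compound 4 the step of a 1.1-fold higher number from compound 3 to compound 4 (0.03 log units; within the scatter) is expected, beside the earlier 1.1-fold higher number from compound 1 to compound 2 (0.03 log units; within the scatter), because a 1.1-fold higher number from compound 1 to compound 2 (0.03 log units; within the scatter) stayed within the scatter when the same exchange was made once before. Compound 4 is therefore estimated at 26 ug/mL in this assay. Going by the values given here, its expected range for compound 4 runs from 15 ug/mL to 45 ug/mL, resting on only one prior instance of the change.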

Compound 4, half-maximal inhibitory concentration: 26.1 ug/mL
Beside the measured number, compound 4's estimate is 1.0-fold (0.00 log units) below it; the measured number falls inside the stated range.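

Read in this assay the exchange of nitro for chloro gave a 1.1-fold higher number from compound 3 to compound 4 (0.03 log units; within the scatter) and thus stands alongside the earlier 1.1-fold higher number from compound 1 to compound 2 (0.03 log units; within the scatter) on the core of compound 1. Across these two cores, then, the exchange of nitro, with its 3 heavy atoms and 2 hydrogen-bond acceptors, for chloro, with 1 heavy atom and no hydrogen-bond acceptors, stayed within the scatter both times, including where it sits para to a large group in compound 4. For the compounds shown here, this shows only that the two groups could not be told apart in these two pairs, not that the same would hold on any other core or at any other place, and no measurement given here bears on why the result came out this way.

The compounds shown leave open whether another group in the same place, such as an amine, a carboxylic acid or a longer chain, would also stay within the scatter in this assay or move the number beyond it. They also leave open what a fluoro or a methoxy group would do in place of the second chloro that compound 3 and compound 4 share on their other aromatic ring.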